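Benzyl substituent series: trifluoromethyl replaced by hydrogen

The compounds below may be only part of what the source reports. "The series", "measured", "known", "first", "only" and "open" are said of these compounds alone.

Compound 1 `CC(C)(C)c1ccc(CNCCCNS(=O)(=O)c2cc(C(F)(F)F)cc(C(F)(F)F)c2)cc1`: in a functional assay on ASPC1 cells (Homo sapiens) for inhibition, read by MTT assay, with a stated time of 72 h (on this read-out lower numbers stand for stronger inhibition of growth and higher numbers for weaker inhibition of growth), compound 1 gives 2700 nM.
Compound 2 `O=S(=O)(NCCCNCc1ccc(Cl)c(Cl)c1)c1cc(C(F)(F)F)cc(C(F)(F)F)c1`: in this assay compound 2 gives 2800 nM.
Compound 3 `O=S(=O)(NCCCNCc1ccc(C(F)(F)F)cc1)c1cc(C(F)(F)F)cc(C(F)(F)F)c1`: in this assay compound 3 gives 2000 nM.

Compound 3 gives the smallest of the three numbers, but the step of a 1.4-fold lower number from compound 1 to compound 3 (0.13 log units; within the scatter) and the step of a 1.4-fold lower number from compound 2 to compound 3 (0.15 log units; within the scatter) both lie within the scatter, so the three compounds are not separated in this assay. Compound 4 `O=S(=O)(NCCCNCc1ccccc1)c1cc(C(F)(F)F)cc(C(F)(F)F)c1` differs from compound 3 by hydrogen in place of trifluoromethyl on an aromatic carbon. The measured steps that bear on this change are those that alter the same benzyl group on the shared core: a 1.4-fold lower number from compound 1 to compound 3 (0.13 log units; within the scatter), a 1.4-fold lower number from compound 2 to compound 3 (0.15 log units; within the scatter) and a 1.0-fold higher number from compound 1 to compound 2 (0.02 log units; within the scatter), each within the scatter. Three different groups at that position thus leave the number in this assay unchanged beyond the scatter. For the measured compounds named here, no measured pair shows what a bare hydrogen does at that position, so the expectation rests only on the indifference seen among compounds 1, 2 and 3, and nothing there points to a step beyond the scatter. The expected step from compound 3 is a 1.4-fold higher number from compound 3 to compound 4 (0.15 log units; within the scatter), that is, none beyond the scatter. For compound 4 the estimate in this assay is 2800 nM, with a range from 1300 nM to 6000 nM.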

Compound 4, concentration for 50% growth inhibition: 13000 nM
Estimate against measurement, compound 4: 4.6-fold (0.67 log units) below, outside the stated range (above it).
By their numbers in this assay, from the lowest: compounds 3, 1 and 2 (each within the scatter of the next); then compound 4.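

In this assay the bare phenyl of compound 4 separates from all three substituted benzyl compounds, with a 6.5-fold higher number from compound 3 to compound 4 (0.81 log units; beyond the scatter) and with a 4.8-fold higher number from compound 1 to compound 4 (0.68 log units; beyond the scatter) and with a 4.6-fold higher number from compound 2 to compound 4 (0.67 log units; beyond the scatter) as the three steps, each beyond the scatter. The position is therefore not indifferent to this change: tert-butyl, trifluoromethyl and 3,4-dichloro substitution cannot be told apart here, and only the compound carrying hydrogen in place of these groups stands apart, so within these four compounds the presence of a substituent counts for more than which of the three it is, and none of the four goes against this. Nothing measured explains why the number rises when the group is removed.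

From the compounds shown here alone, what remains open is how small a group can be and still keep the number near that of compounds 1, 2 and 3, as a single fluorine or a methyl would test at this position. Also open, going by these compounds, is whether a methoxy, an amine or a carboxylic acid there would fall with the three substituted compounds or with compound 4.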